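From dichlorophenyl to nitrophenyl in a growth-inhibition series

The compounds below may be only part of what the source reports. "The series", "measured", "known", "first", "only" and "open" are said of these compounds alone.

Compound 1 `O=C(/C(=C/c1ccc(Br)cc1)S(=O)(=O)Cc1ccc(I)cc1)c1ccc(I)cc1` gives 20000 nM
Compound 2 `O=C(/C(=C\c1ccc(O)c([N+](=O)[O-])c1)SCc1ccc(Br)cc1)c1ccc(Cl)cc1Cl` gives 10000 nM
Compound 3 `O=C(/C(=C\c1c[nH]c2ccccc12)Sc1ccc(Br)cc1)c1ccc(Br)cc1` gives 1000 nM

All three compounds were tested in a functional assay on DU-145 cells (Homo sapiens) for inhibition, read by trypan blue exclusion, with a stated time of 96 h (on this read-out higher numbers stand for weaker inhibition of growth and lower numbers for stronger inhibition of growth), and no two of them differ in just one place. Compound 2 (10000 nM) and compound 1 (20000 nM) lie within the scatter of each other. Compound 3 (1000 nM) gives a lower number than compound 2 by more than the scatter, which means stronger inhibition of growth.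

Compound 4 `O=C(/C(=C\c1ccc(O)c([N+](=O)[O-])c1)SCc1ccc(Br)cc1)c1ccc([N+](=O)[O-])cc1` has not been measured yet. It differs from compound 2 in one place (4-nitrophenyl in place of 2,4-dichlorophenyl on a carbonyl carbon): 4-nitrophenyl in place of 2,4-dichlorophenyl on a carbonyl carbon. Within the data shown here, none of the measured compounds shows this exchange, so the data give no direct guide to its size. The expectation therefore starts from compound 2 (10000 nM) as the closest measured structure. The expected step in this assay is a 1.3-fold lower number from compound 2 to compound 4 (0.10 log units; within the scatter) and would stay within the scatter, with no firm direction. For compound 4 the estimated value is 8000 nM (expected range 2500 nM to 25000 nM).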

Compound 4, concentration for 50% growth inhibition: 10000 nM
Beside the measured number, compound 4's estimate is 1.3-fold (0.10 log units) below it, and the stated range covers the measured number.
By their numbers in this assay, from the lowest: compound 3; then compounds 2, 4 and 1 (each within the scatter of the next).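

Among these compounds, this is the first pair here that differs in one place, so it gives the first direct reading of the group on a carbonyl carbon: in this assay, 4-nitrophenyl in place of 2,4-dichlorophenyl gives no change at the digits printed from compound 2 to compound 4 (within the scatter). At this position, the read-out therefore does not separate these two rings, even though the entering group adds hydrogen-bond acceptors and a nitrogen, and the leaving group carries two chlorine atoms. Nothing available accounts for this result.

From the compounds shown here alone, it remains open whether a phenyl ring carrying an amine or a carboxylic acid, or a longer chain in place of the ring, would read the same at this position. Going by these compounds, it is also open whether this exchange would give the same step if another part of compound 2 were different.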